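The source may report more compounds than this note shows. Statements on the series, on what has been measured and on what is new or still open speak of the compounds shown alone.

The measured compounds:
Compound 1 `Fc1ccc(-c2nn3c(NC4CCCC4)cccc3c2-c2ccncc2)cc1`, 20000 nM in an ADME assay on Vero cells (Chlorocebus sabaeus) for cytotoxicity; a lower number here means that less compound is tolerated, a higher number that more compound is tolerated.
Compound 2 `Cc1nc(-c2c(-c3ccc(F)cc3)nn3c(NC4CCCC4)cccc23)co1`, "not determined" (no result reported) in this assay.
Compound 3 `Fc1ccc(-c2nn3c(NC4CCCC4)cccc3c2-c2ccc(F)nc2)cc1`, "not determined" (no result reported) in this assay.

Of the three, only compound 1 carries a number in this assay, where compound 1 gives 20000 nM. Compound 3 stands without a number in this assay, and the same holds for compound 2, so compound 3 cannot be placed against either of the others on this read-out; it stands apart from compound 1 simply as an untested member of the shared core.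

The step to compound 4 `NNc1cc(-c2c(-c3ccc(F)cc3)nn3c(NC4CCCC4)cccc23)ccn1` brings a change in one place: 2-(aminoamino)pyridin-4-yl in place of 6-fluoropyridin-3-yl on an aromatic carbon. Going by the values given here, no measured pair shares this change, and compound 3 itself has no value, so the direction and size of the step in this assay cannot be read from the data. With compound 1 as the only anchor for the series, the expected step is none beyond the scatter in either direction, and a result reported only as a limit is quite possible.

Compound 4 is therefore expected to give about 20000 nM in this assay, with a range from 5000 nM to 100000 nM.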

Compound 4, half-maximal cytotoxic concentration: 40000 nM
Estimate against measurement, compound 4: 2.0-fold (0.30 log units) below; the measured number falls inside the stated range.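

Going by these compounds alone, with the 2-(aminoamino)pyridin-4-yl group on the shared core, the first readable step in this assay is a 2.0-fold higher number from compound 1 to compound 4 (0.30 log units; within the scatter), for aminoamino in place of hydrogen on an aromatic carbon. Within the data shown here, the pair therefore shows that this addition to the ring attached at this position, on the aromatic carbon next to the ring atom that bears the 4-fluorophenyl group, leaves the read-out within the usual scatter, which the earlier compounds could not show with only one number among them. No measurement shown here accounts for this outcome.

On these data alone, the steps involving compound 2 or compound 3 cannot be read, so the effect of exchanging 6-fluoropyridin-3-yl for 2-(aminoamino)pyridin-4-yl, and of the methyl-bearing five-membered ring of compound 2, remains unknown on this read-out. As far as these compounds go, it also remains open whether a simple amine, a carboxylic acid or a longer chain on that same aromatic carbon would stay within the scatter of compound 1 as aminoamino does, since a single pair cannot define a trend for this position.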